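The source may report more compounds than this note shows. Statements on the series, on what has been measured and on what is new or still open speak of the compounds shown alone.

Measured so far in an assay on isolated protein (urine) for inhibition of Myeloperoxidase (Homo sapiens), with a stated time of 5 min; on this read-out higher numbers stand for weaker inhibition and lower numbers for stronger inhibition:
- compound 1, `CCCc1c[nH]c2ccc(F)cc12`
- compound 2, `NC(=O)CCCCc1c[nH]c2ccc(F)cc12`: 39 nM
- compound 3, `CNC(=O)CCCc1c[nH]c2ccc(F)cc12`: 40 nM

Compound 1 gives > 100 nM in this assay, which is a limit of the assay and not a number (the limit of > 100 nM in this assay, at which 1 of the 3 values shown sits). Against that limit, the steps are an at least 2.5-fold lower number from compound 1 to compound 2 (0.40 log units; beyond the scatter) and an at least 2.5-fold lower number from compound 1 to compound 3 (0.39 log units; beyond the scatter). Between the two numbers, compound 3 stands highest, with compound 2 nearest: a 1.0-fold higher number from compound 2 to compound 3 (0.01 log units; within the scatter).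

Compound 4 is `NC(=O)CCCc1c[nH]c2ccc(F)cc12`. Relative to compound 3 the change is hydrogen in place of methyl on an amide-type nitrogen. Among the compounds with values here, no measured step removes a methyl from the amide nitrogen. Within the data shown here, the one step that reshapes the amide end, from compound 2 to compound 3, is a 1.0-fold higher number from compound 2 to compound 3 (0.01 log units; within the scatter), and it stays within the scatter, so the amide end appears tolerant of small rearrangement on these three compounds. The step to compound 4 is therefore expected to be no change at the digits printed from compound 3 to compound 4 (within the scatter), no change beyond the scatter in this assay. The expected value for compound 4 is 40 nM, estimated within 15 nM to 110 nM.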

Compound 4, half-maximal inhibitory concentration: 18 nM
The estimate for compound 4 lay 2.2-fold (0.35 log units) above the measured number, and the stated range covers the measured number.
By their numbers in this assay, from the lowest: compound 4; then compounds 2 and 3 (each within the scatter of the next). At a limit, above all of these: compound 1.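

In this assay, within the data shown here, the amide nitrogen is now a place where a small change registers: a 2.2-fold lower number from compound 3 to compound 4 (0.35 log units; beyond the scatter), whereas the one earlier step at the amide end stayed within the scatter. Trimming the chain also counts once the amide nitrogen carries only hydrogen, with a 2.2-fold lower number from compound 2 to compound 4 (0.34 log units; beyond the scatter), so the carbamoyl on this chain separates from both compound 2 and compound 3, which sit within the scatter of each other. The carbamoyl end also gives the largest printed gain over the propyl compound, an at least 5.5-fold lower number from compound 1 to compound 4 (0.74 log units; beyond the scatter), but compound 1 is held at a limit and not a number: the limit of > 100 nM in this assay, at which 1 of the 4 values shown sits.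

Still open, on these data alone, is whether a carboxylic acid or a nitrile in place of the carbamoyl would hold this level. As far as these compounds go, it is equally open whether a shorter chain would go lower still, and whether an ethyl on the amide nitrogen would follow the methyl.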